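Aryl swap on the anilide nitrogen: compound 2 to compound 4

This account rests on a few compounds, and the source may have more. Where it says the series, first, only, none or still open, it means among the compounds named here.

Compound 2 `O=C(CSc1nc(Nc2ccccc2)c2ccccc2n1)Nc1cccc(Br)c1` gives 9620 nM in a functional assay on MGC-803 cells (Homo sapiens) for inhibition, read by MTT assay, with a stated time of 72 h; a lower number here means a stronger inhibitor, a higher number a weaker inhibitor. Against compound 1 `O=C(CSc1nc(Nc2ccccc2)c2ccccc2n1)Nc1ccccc1F` at 10700 nM and compound 3 `C=CC(=O)Nc1cccc(NC(=O)CSc2nc(Nc3ccccc3)c3ccccc3n2)c1` at 7310 nM, compound 2 sits within the scatter of both, so no order among the three can be read. Compound 4 `O=C(CSc1nc(Nc2ccccc2)c2ccccc2n1)Nc1ccc(F)cc1` differs from compound 2 by 4-fluorophenyl in place of 3-bromophenyl on an amide-type nitrogen. Among the measured compounds shown here, the steps that bear on the aryl group at this nitrogen are a 1.1-fold lower number from compound 1 to compound 2 (0.05 log units; within the scatter), a 1.5-fold lower number from compound 1 to compound 3 (0.17 log units; within the scatter) and a 1.3-fold lower number from compound 2 to compound 3 (0.12 log units; within the scatter); none left the scatter, though none is the bromo-to-fluoro exchange itself. The expected step is therefore a 1.0-fold higher number from compound 2 to compound 4 (0.02 log units; within the scatter), none beyond the scatter. Compound 4 is expected at 10000 nM, between 5000 nM and 20000 nM.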

Compound 4, half-maximal inhibitory concentration: > 50000 nM
Compound 4 gave a limit, no number (the forecaster's own chance of this, stated with the estimate: 5%); middle value at least 5.0-fold (0.69 log units) from the limit.
By their numbers in this assay, from the lowest: compounds 3, 2 and 1 (each within the scatter of the next). At a limit, above all of these: compound 4.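

In this assay the aryl group on the amide-type nitrogen is not indifferent, as compounds 1, 2 and 3 alone left it: an at least 5.1-fold higher number from compound 2 to compound 4 (0.71 log units; beyond the scatter), and an at least 6.8-fold higher number from compound 3 to compound 4 (0.83 log units; beyond the scatter). Fluorine alone does not account for the change, since 2-fluorophenyl and 4-fluorophenyl are separated by an at least 4.6-fold higher number from compound 1 to compound 4 (0.66 log units; beyond the scatter). Compound 4 gives a limit, not a number: the limit of > 50000 nM in this assay, at which 1 of the 4 values shown sits.

From the compounds shown here alone, the full size of these steps stays open. So does whether 4-bromophenyl, or an amine on the same aryl ring, would follow compound 4 or compound 2.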